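A few compounds are considered here, and "the series" means these few. Any claim that something is new, unique, unknown or untested is made for them only; others in the source may bear on it.

Compound 1 `CCNc1cc(-c2ccc(NC(=O)Nc3cccc(Cl)c3)cc2C(F)(F)F)ccn1` gives 94.9% in an assay on isolated protein for inhibition of serine/threonine-protein kinase PLK1 (Homo sapiens), read by radiometric assay and 33P incorporation, with a stated time of 40 min, tested at 20 uM, in the presence of a further agent that is not named here; on this read-out higher numbers stand for more inhibition at the one concentration tested (going by the name of the read-out) and lower numbers for less inhibition.
Compound 2 `O=C(Nc1cccc(Cl)c1)Nc1ccc(-c2ccnc(NCC3CC3)c2)c(C(F)(F)F)c1` gives 63.8%.
Compound 3 `O=C(Nc1ccc(C(F)(F)F)cc1)Nc1ccc(-c2ccnc(NCC3CC3)c2)c(C(F)(F)F)c1` gives 53.4%.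

Among these three, compound 2 stands in the middle: compound 1 lies above it and compound 3 below it, and both of those gaps are beyond the usual scatter of the read-out.

The new compound, compound 4 `CCCNc1cc(-c2ccc(NC(=O)Nc3cccc(Cl)c3)cc2C(F)(F)F)ccn1`, differs from compound 2 in one place: ethyl in place of cyclopropyl on a saturated chain carbon bound to a nitrogen on an aromatic ring. The chain that hangs from the nitrogen on the aromatic ring is thus shortened, reading one bond further out as cyclopropylmethyl to propyl.

Going by the values given here, only one measured step touches this part of the molecule, the change from methyl to cyclopropyl on that same saturated chain carbon, which gave a number 31.1 percentage points lower from compound 1 to compound 2 (beyond the scatter). The step from 3-chlorophenyl to 4-(trifluoromethyl)phenyl, a number 10.4 percentage points lower from compound 2 to compound 3 (beyond the scatter), concerns a different end of the molecule and says nothing about the chain. Ethyl lies between methyl and cyclopropyl in the count of carbon atoms, so compound 4 is expected to recover part of what compound 2 lost, an expected step of a number 16.2 percentage points higher from compound 2 to compound 4 (beyond the scatter). Compound 4 is therefore estimated at 80%, with a range from 62% to 95%.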

Compound 4, a percentage reported as inhibition, at one concentration (the size of the read-out at that concentration, not a potency): 63%
Estimate against measurement, compound 4: 17 percentage points above, within the range that was stated.
By their numbers in this assay, from the lowest: compounds 3, 4 and 2 (each within the scatter of the next, the first and the last beyond it); then compound 1.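

Replacing cyclopropyl with ethyl on the saturated chain carbon turns cyclopropylmethyl into propyl, and in this assay this gives a number 0.8 percentage points lower from compound 2 to compound 4 (within the scatter), so an open chain and a chain ending in a three-membered ring cannot be told apart here. Placing methyl instead of hydrogen on the saturated chain carbon, two bonds along the chain from the nitrogen on the aromatic ring, gives a number 31.9 percentage points lower from compound 1 to compound 4 (beyond the scatter), which shows that the large gap to compound 1 does not require the ring and appears with the plain propyl chain as well. Nothing available here explains this pattern.

The compounds shown leave open whether a longer chain such as butyl would sit at the level of compound 2 and compound 4 or lower still, and whether a shorter methyl group on the nitrogen would match compound 1 or exceed it. Branched isopropyl and a chain carrying a hydroxyl group, such as 2-hydroxyethyl, also remain open, and they could show whether the shape of the chain matters as well as its length.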